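The compounds below may be only part of what the source reports. "The series", "measured", "known", "first", "only" and "open" are said of these compounds alone.

Compound 1 `CNC(=O)c1cc(C(=O)N[C@H]2CC[C@H](O)CC2)n([C@@H](C)c2cccc(Cl)c2)n1`: 235 nm/s
Compound 2 `CNC(=O)c1cc(C(=O)N[C@H]2CC[C@H](OC)CC2)c([C@@H](C)c2ccccc2)o1`: 303 nm/s
Compound 3 `CNC(=O)c1cc(C(=O)N[C@H]2CC[C@H](OC)CC2)n([C@@H](C)c2ccccc2)n1`: 360 nm/s

Of the compounds shown here, three have so far been measured in an ADME assay for permeability; on this read-out lower numbers stand for lower permeability and higher numbers for higher permeability. Compound 2 gives 303 nm/s and stands second highest of the three numbers. Its nearest neighbour, compound 3, gives 360 nm/s, a gap that lies within the usual scatter, and compound 1, the furthest away, gives 235 nm/s, also within the scatter. On these numbers the three compounds cannot be told apart in this assay.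

Compound 4 `CNC(=O)c1cc(C(=O)N[C@H]2[C@@H]3C[C@@H](O)C[C@@H]32)c([C@@H](C)c2ccccc2)o1` has not yet been measured. It differs from compound 2 in one place:

a group of 7 heavy atoms (6 carbon, 1 oxygen; one three-membered non-aromatic ring of carbon only, one five-membered non-aromatic ring of carbon only) in place of a group of 8 heavy atoms (7 carbon, 1 oxygen; one six-membered non-aromatic ring of carbon only), on an amide-type nitrogen

Going by the values given here, no measured pair shows this exact change, so there is no step to lean on. The closest hint comes from compound 1, whose ring carries a hydroxyl and which gives 235 nm/s, set against compound 3, whose ring carries a methoxy and which gives 360 nm/s; these two differ elsewhere as well, and their gap is within the scatter. The step from compound 2 to compound 4 is thus expected to be modest and downward, if anything beyond the scatter at all: a 1.7-fold lower number from compound 2 to compound 4 (0.23 log units; within the scatter). Compound 4 is estimated at 180 nm/s, with a range from 100 nm/s to 320 nm/s.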

Compound 4, apparent permeability: 45 nm/s
Compound 4: the middle estimate sits 4.0-fold (0.60 log units) above what was measured; the whole stated range lies above it.
By their numbers in this assay, from the lowest: compound 4; then compounds 1, 2 and 3 (each within the scatter of the next).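

In this assay, going by these compounds alone, the group on the amide-type nitrogen proves able to move the number well beyond the scatter: replacing 4-methoxycyclohexyl with the group holding a three-membered and a five-membered carbon ring brings a 6.7-fold lower number from compound 2 to compound 4 (0.83 log units; beyond the scatter), whereas the earlier compounds could not be told apart. This one change alters several things at once, since the ring system differs, the hydrogen-bond donors go from 0 to 1, and the defined stereocentres go from 2 to 4, so the step measures them only as a bundle. Nothing measured here explains the drop or assigns it to any one of these features.

On these data alone, what remains open is how much of the step belongs to the new ring system and how much to the hydroxyl in place of the methoxy, a question that a methoxy on the new ring, or a 4-hydroxycyclohexyl, on the core of compound 2 would help to settle. The compounds shown also leave open how an amine or a carboxylic acid in that place on the ring would read in this assay.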